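The source may hold more compounds than are shown below. What is called first, only, known or untested is meant among the compounds shown, and "the series" means these compounds.

Measured compounds:
- compound 1 `C=CC(=O)N1CC[C@H](N2C(=O)N(c3ccccc3)Cc3cnc(Nc4ccc(N5CCN(C)CC5)cc4)nc32)C1` — 2830 nM
- compound 2 `C=CC(=O)N1CC[C@H](N2C(=O)N(c3ccccc3)Cc3cnc(Nc4ccc(N5CCN(C)CC5)cc4OC)nc32)C1` — 3150 nM
- compound 3 `C=CC(=O)N1CC[C@H](N2C(=O)N(c3ccccc3)Cc3cnc(Nc4ccccc4)nc32)C1` — 14900 nM

In an ADME assay on the whole organism (strain Sprague-Dawley) for pharmacokinetics, with Rattus norvegicus as the target, read by LC-MS, at a dose of 5 mg/kg by the intravenous route (on this read-out higher numbers stand for higher exposure at the dose given and lower numbers for lower exposure), compound 1 gives 2830 nM, the lowest of the three numbers; compound 2 sits within the scatter of it, while compound 3 is clearly higher. Compound 4 `C=CC(=O)N1CC[C@H](N2C(=O)N(c3ccccc3)Cc3cnc(Nc4ccc(N5CCN(C)CC5)c(OC)c4)nc32)C1` differs from compound 1 by methoxy in place of hydrogen on an aromatic carbon. The most comparable measured step is a 1.1-fold higher number from compound 1 to compound 2 (0.05 log units; within the scatter), also a methoxy in place of hydrogen on an aromatic carbon, though at a different place. The other step, a 5.3-fold higher number from compound 1 to compound 3 (0.72 log units; beyond the scatter), removes the 4-methylpiperazin-1-yl group entirely and so bears less on this change. On that basis the expected step is a 1.1-fold higher number from compound 1 to compound 4 (0.03 log units; within the scatter), no clear move beyond the scatter. Compound 4 is therefore estimated at 3000 nM, in a range from 1500 nM to 6000 nM.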

Compound 4, maximal plasma concentration: 5990 nM
Beside the measured number, compound 4's estimate is 2.0-fold (0.30 log units) below it; measured number inside the range.
By their numbers in this assay, from the lowest: compounds 1, 2 and 4 (each within the scatter of the next, the first and the last beyond it); then compound 3.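

In this assay, methoxy ortho to a 4-methylpiperazin-1-yl group gives a 2.1-fold higher number from compound 1 to compound 4 (0.33 log units; beyond the scatter) and so clears the scatter, while methoxy at another place gives a 1.1-fold higher number from compound 1 to compound 2 (0.05 log units; within the scatter) and does not. Even so, compounds 2 and 4 lie within the scatter of each other, so these two places are not truly separated. Nothing measured here explains the step. On these data alone, whether an ethoxy group or a fluorine atom at this place would act like methoxy stays open, as does whether methoxy here would give a similar step without the 4-methylpiperazin-1-yl group.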